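A few compounds are considered here, and "the series" means these few. Any claim that something is new, unique, unknown or untested is made for them only; others in the source may bear on it.

Measured in a functional assay on U-87MG ATCC cells for inhibition, with U-87 MG (Homo sapiens) as the target, read by MTT assay, with a stated time of 72 h; on this read-out higher numbers stand for weaker inhibition and lower numbers for stronger inhibition:
- Compound 1 `COc1ccc(C(Nc2cc(C)ccn2)c2ccc3cccnc3c2O)cc1O`: > 10000 nM
- Compound 2 `Cc1ccnc(NC(c2ccccc2C)c2ccc3cccnc3c2O)c1`: > 10000 nM
- Compound 3 `CCc1ccc(C(Nc2cc(C)ccn2)c2ccc3cccnc3c2O)cc1`: 8900 nM

Compound 1 gives > 10000 nM, which is a limit of the assay and not a number. For compound 2, > 10000 nM is likewise a limit. The set therefore shows (the limit of > 10000 nM in this assay, at which 2 of the 3 values shown sit). Among the compounds with values here, compound 3, at 8900 nM, holds the only actual number.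

Compound 4 `Cc1ccnc(NC(c2ccc3cccnc3c2O)c2c(Cl)cccc2Cl)c1`, still to be measured, differs from compound 3 in one group: 2,6-dichlorophenyl in place of 4-ethylphenyl on a saturated chain carbon bound to an aromatic carbon and a nitrogen on an aromatic ring. It carries 2,6-dichlorophenyl in place of 4-ethylphenyl on a saturated chain carbon bound to an aromatic carbon and a nitrogen on an aromatic ring.

Three measured steps exchange the group at this same place. Within the data shown here, the first is a step that the two limits leave unreadable from compound 1 to compound 2, which cannot be sized. The other two are an at least 1.1-fold lower number from compound 1 to compound 3 (0.05 log units; that floor lies within the scatter) and an at least 1.1-fold lower number from compound 2 to compound 3 (0.05 log units; that floor lies within the scatter), and the floor of each lies within the scatter. None of the three therefore shows a change beyond the scatter, so no step beyond the scatter is expected in this assay, in either direction. The expected step is a 1.0-fold higher number from compound 3 to compound 4 (0.00 log units; within the scatter). A report of a limit alone is also quite possible for this compound. Compound 4 is estimated at 9000 nM, with an expected range from 3000 nM to 20000 nM.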

Compound 4, half-maximal inhibitory concentration: 7200 nM
Compound 4: middle estimate off by 1.3-fold (0.10 log units), on the high side; the range from low to high includes it.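

Within the data shown here, at this place, on a saturated chain carbon bound to an aromatic carbon and a nitrogen on an aromatic ring, compound 4 gives the first step in this assay that joins two actual numbers: 2,6-dichlorophenyl in place of 4-ethylphenyl gives a 1.2-fold lower number from compound 3 to compound 4 (0.09 log units; within the scatter), so the two groups cannot be told apart here. Exchanging a ring that carries an ethyl group for one that carries two chlorine atoms, with the heavy-atom count unchanged, therefore does not move the number beyond the scatter. Against the other two compounds the result gives only floors, an at least 1.3-fold lower number from compound 2 to compound 4 (0.14 log units; that floor lies within the scatter) and an at least 1.3-fold lower number from compound 1 to compound 4 (0.14 log units; that floor lies within the scatter), each resting on a limit rather than a number, and neither floor shows a change beyond the scatter: the limit of > 10000 nM in this assay, at which 2 of the 4 values shown sit.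

Every group shown at this place is a substituted phenyl, so what an amine, a carboxylic acid or a longer alkyl chain would do here remains open. Also open, going by these compounds, is how far compound 1 and compound 2 truly lie from compound 3 and compound 4, and whether any exchange at this place can produce a step beyond the scatter.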